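A few compounds are considered here, and "the series" means these few. Any claim that something is new, unique, unknown or untested is made for them only; others in the source may bear on it.

Compound 1 `O=C(CN1CCN(c2nnc(Cc3ccncc3)c3ccccc23)CC1)Nc1ccc(F)c(Cl)c1` and compound 2 `O=C(CN1CCN(c2nnc(Cc3ccncc3)c3ccccc23)CC1)Nc1ccc(Br)cc1` differ only in the group on the amide-type nitrogen of the shared core. In a functional assay on A549 cells (Homo sapiens) for cytotoxicity, read by MTT assay, with a stated time of 72 h (a lower number here means a stronger inhibitor, a higher number a weaker inhibitor), compound 1 gives 12300 nM and compound 2 gives 2710 nM, a step of a 4.5-fold lower number from compound 1 to compound 2 (0.66 log units; beyond the scatter). Compound 3 `Cc1ccc(F)cc1NC(=O)CN1CCN(c2nnc(Cc3ccccc3)c3ccccc23)CC1` differs from both in the core substituent as well as on the amide-type nitrogen; in this assay compound 3 is reported as "not active" (no number reported), so no single number places it on the scale. Compound 4 `Cc1ccccc1NC(=O)CN1CCN(c2nnc(Cc3ccccc3)c3ccccc23)CC1` differs from compound 3 by hydrogen in place of fluoro on an aromatic carbon. The step from compound 1 to compound 2 also changed the group on the amide-type nitrogen and was modest; the present change is smaller, so no step beyond the scatter is expected, and the starting point gives no number. Compound 4 is expected to stay weak in this assay, estimated near 30000 nM with a range of 8000 nM to 150000 nM.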

Compound 4, half-maximal inhibitory concentration: "not active" (no number reported)
For compound 4 the study gives words and no number; there is nothing to compare the estimate with.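

Compound 3 and compound 4 are both reported only in words in this assay, so no step can be read between them. No supporting evidence bears on this result. The compounds shown leave open what replacing fluoro with hydrogen does to potency.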